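The source may report more compounds than this note shows. Statements on the series, on what has been measured and on what is new or still open speak of the compounds shown alone.

Measured in a functional assay on MCF7 cells (Homo sapiens) for inhibition; on this read-out higher numbers stand for weaker inhibition and lower numbers for stronger inhibition:
Compound 1 `N[C@H]1CC[C@H](Nc2nc(NCc3cccc(I)c3)c3ncn(C4CCCC4)c3n2)CC1`: 600 nM
Compound 2 `N[C@H]1CC[C@H](Nc2nc(NCC3CC3)c3ncn(C4CCCC4)c3n2)CC1`: 1300 nM

Of these two compounds, compound 2 has the higher number, 1300 nM, and so the weaker inhibition. Compound 3 `C[C@H](Nc1nc(N[C@H]2CC[C@H](N)CC2)nc2c1ncn2C1CCCC1)c1ccccc1` differs from it as follows: 1-phenylethyl in place of cyclopropylmethyl on a nitrogen on an aromatic ring. Among the compounds with values here, only one measured step bears on this change: a 2.2-fold higher number from compound 1 to compound 2 (0.34 log units; beyond the scatter). Within the data shown here, that modest step links a ring-bearing group to the lower number, but no measured compound carries a defined stereocentre in this group. A modest move towards stronger inhibition is therefore expected, with an estimated step of a 1.6-fold lower number from compound 2 to compound 3 (0.21 log units; within the scatter). In this assay, compound 3 is expected at 800 nM, with an estimated range of 250 nM to 2500 nM.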

Compound 3, half-maximal inhibitory concentration: 3300 nM
Compound 3: middle estimate off by 4.1-fold (0.62 log units), on the low side; measured number outside the range, above it.
By their numbers in this assay, from the lowest: compound 1; then compound 2; then compound 3.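

In this assay, an aromatic ring on this nitrogen does not by itself bring the lower number: changing cyclopropylmethyl to 1-phenylethyl gives a 2.5-fold higher number from compound 2 to compound 3 (0.40 log units; beyond the scatter). Against 3-iodobenzyl, the same group gives a 5.5-fold higher number from compound 1 to compound 3 (0.74 log units; beyond the scatter), so two ring-bearing groups on this nitrogen differ clearly. No measurement here explains these differences. Going by these compounds, what remains open is whether the iodine of compound 1 or the branching of compound 3 matters more. An unsubstituted benzyl group, or 1-phenylethyl of the opposite handedness, would help to separate these two features.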